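Swapping Methoxy for Bromo on a Weak Benzyl Series

The source may hold more compounds than are shown below. What is called first, only, known or untested is meant among the compounds shown, and "the series" means these compounds.

Measured so far:
- Compound 1 `c1ccc(CSc2nnc(-c3ccc4c(c3)OCCO4)n2-c2ccccc2)cc1` gives 73400 nM in a functional assay on BGC-823 cells (Homo sapiens) for antiproliferative activity, read by MTT assay, with a stated time of 24 h; a lower number here means a stronger inhibitor, a higher number a weaker inhibitor.
- Compound 2 `COc1cccc(CSc2nnc(-c3ccc4c(c3)OCCO4)n2-c2ccccc2)c1` gives a result in this assay that is only an assay limit, > 100000 nM.

Compound 2 therefore stands at the weak end of what has been measured: its value is a limit, not a number, and it is the one of the two results that sits at the limit of > 100000 nM in this assay, at which 1 of the 2 values shown sits. Going by the values given here, the only measured step, an at least 1.3-fold higher number from compound 1 to compound 2 (0.13 log units; that floor lies within the scatter), is small and lies within the scatter, so methoxy in place of hydrogen on the aromatic carbon did not clearly change the read-out.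

Compound 3 `Brc1cccc(CSc2nnc(-c3ccc4c(c3)OCCO4)n2-c2ccccc2)c1` has not yet been measured. It differs from compound 2 by bromo in place of methoxy on an aromatic carbon. Among the compounds with values here, no measured step involves a bromo group, so the only guidance is that both known compounds are weak and the one step between them was within the scatter. The step from compound 2 is therefore expected to be small in either direction: an at least 1.2-fold lower number from compound 2 to compound 3 (0.09 log units; that floor lies within the scatter). For compound 3 the expected value in this assay is 80000 nM, with a range from 30000 nM to 200000 nM.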

Compound 3, half-maximal inhibitory concentration: 65600 nM
For compound 3 the middle estimate is 1.2-fold (0.09 log units) above the measured one; measured number inside the range.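

Compound 2 is still held by an assay limit rather than a number: the limit of > 100000 nM in this assay, at which 1 of the 3 values shown sits. Replacing its methoxy with bromo gives an at least 1.5-fold lower number from compound 2 to compound 3 (0.18 log units; that floor lies within the scatter), so this step has a floor but no known size, and that floor does not show a clear change. Compound 3 does add something new, a measured number for a compound with a group at this place on the ring: bromo in place of hydrogen gives a 1.1-fold lower number from compound 1 to compound 3 (0.05 log units; within the scatter), so in this assay this one group, on an aromatic carbon and meta to a large group, leaves the read-out indistinguishable from that of compound 1.

As far as these compounds go, it remains open whether any group at this place can move the number beyond the scatter, for example an amine or a carboxylic acid on the same ring carbon. The compounds shown also leave open what changes elsewhere on the shared core would do, such as a longer chain in place of the benzyl group's single carbon link to sulfur.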